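The source may report more compounds than this note shows. Statements on the series, on what has been measured and on what is new or still open speak of the compounds shown alone.

Going by the values given here, compound 2 `CC/C(=C(/c1ccc(/C=C/C(=O)O)cc1)c1cc2ccccc2[nH]1)c1ccc(C#N)cc1Cl` gives 49 nM in a functional assay on MCF7 cells (Homo sapiens) for inhibition (a lower number here means a stronger inhibitor, a higher number a weaker inhibitor), the lowest of the two numbers measured so far. Compound 1 `CC/C(=C(/c1ccc(/C=C/C(=O)O)cc1)c1cc2ccccc2[nH]1)c1ccc(C#N)cc1` gives 278 nM in this assay, and the step of a 5.7-fold lower number from compound 1 to compound 2 (0.75 log units; beyond the scatter) came with a chloro in place of hydrogen on an aromatic carbon. Compound 3 `CC/C(=C(/c1ccc(/C=C/C(=O)O)cc1)c1cc2ccccc2[nH]1)c1ccc(Cl)cc1C#N` differs from compound 2 by 4-chloro-2-cyanophenyl in place of 2-chloro-4-cyanophenyl on a double-bonded chain carbon bound to a double-bonded chain carbon and a saturated chain carbon. Among the compounds with values here, no measured step swaps two groups in this way; only the single chloro addition is known, so the direction is uncertain. Compound 3 is expected to give back part of that gain, a step of a 2.7-fold higher number from compound 2 to compound 3 (0.42 log units; beyond the scatter), for an estimated 130 nM with a range from 35 nM to 500 nM.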

Compound 3, half-maximal inhibitory concentration: 14 nM
Estimate against measurement, compound 3: 9.3-fold (0.97 log units) above, outside the stated range (below it).
By their numbers in this assay, from the lowest: compound 3; then compound 2; then compound 1.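

Chloro and nitrile are the same two groups in 2-chloro-4-cyanophenyl and 4-chloro-2-cyanophenyl, yet exchanging these rings on the double-bonded chain carbon gives a 3.5-fold lower number from compound 2 to compound 3 (0.54 log units; beyond the scatter) in this assay. At this position, then, the arrangement of the two groups counts, not only their presence. Against the unchlorinated ring, 4-chloro-2-cyanophenyl gives a 20-fold lower number from compound 1 to compound 3 (1.30 log units; beyond the scatter). Nothing available bears on why the two arrangements differ. The compounds shown leave open whether a methoxy or an amine in place of the chloro would keep this level of inhibition, and whether the nitrile can be replaced by a carboxylic acid.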